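The compounds below may be only part of what the source reports. "The series", "measured", "known", "first", "only" and "open" are said of these compounds alone.

Compounds measured so far in an assay on membranes from HEK293 cells for displacement of a labelled ligand from adenosine receptor A2b (Homo sapiens), read by scintillation counting, with a stated time of 30 min; on this read-out lower numbers stand for stronger inhibition and higher numbers for weaker inhibition:

Compound 1, `CC1=C(C(=O)OCc2ccccc2)C(c2ccco2)NC(=O)N1`: 887 nM
Compound 2, `CC1=C(C(=O)CC(C)C)C(c2ccco2)NC(=O)N1`: 240 nM
Compound 3, `CC1=C(C(=O)CC(C)C)C(c2ccsc2)NC(=O)N1`: 1000 nM

Compound 2 stands at the lowest number of the three, with compound 1 and compound 3 both further up; compound 1 is the nearer of the two. Among the compounds with values here, the only single-point step recorded is a 4.2-fold higher number from compound 2 to compound 3 (0.62 log units; beyond the scatter), which swaps the ring on a saturated ring carbon and has nothing to say about the carbonyl side of the shared core.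

Compound 4, `CC1=C(C(=O)OC2CCCC2)C(c2ccco2)NC(=O)N1`, is reached from compound 2 by cyclopentyloxy in place of isobutyl on a carbonyl carbon. Within the data shown here, no measured step covers this change. The closest guide is compound 1, which also carries an oxygen-linked group on the same carbonyl carbon and gives 887 nM, while compound 2 with its isobutyl gives 240 nM; these two values differ in more than one respect, so they only hint that an oxygen-linked group at this carbonyl may sit at a higher number.

On that basis compound 4 is expected to show a moderate rise, a 2.1-fold higher number from compound 2 to compound 4 (0.32 log units; beyond the scatter), though a result close to compound 2 would not be surprising. The estimate for compound 4 in this assay is 500 nM, with a likely range from 150 nM to 1700 nM.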

Compound 4, inhibition constant: 577 nM
Estimate against measurement, compound 4: 1.2-fold (0.06 log units) below, within the range that was stated.
By their numbers in this assay, from the lowest: compound 2; then compounds 4, 1 and 3 (each within the scatter of the next).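

In this assay, within the data shown here, cyclopentyloxy in place of isobutyl on a carbonyl carbon gives a 2.4-fold higher number from compound 2 to compound 4 (0.38 log units; beyond the scatter), so this is the first single change at this carbonyl, and the new group's extra ring and oxygen come with a rise that can be read beyond the usual noise of the assay. Within the oxygen-linked groups, cyclopentyl in place of benzyl on an oxygen next to a carbonyl group gives a 1.5-fold lower number from compound 1 to compound 4 (0.19 log units; within the scatter), so this pair cannot be told apart, and swapping one of these two groups for the other makes no readable difference in this assay. No measurement at hand explains why the isobutyl and cyclopentyloxy compounds differ.

As far as these compounds go, it remains open whether the rise follows the oxygen link itself or the size of the group, which a small methoxy group or a straight propyl chain on the same carbonyl carbon could help separate, and whether a nitrogen-linked group such as cyclopentylamino would behave like cyclopentyloxy. From the compounds shown here alone, it is also open whether thiophen-3-yl in place of furan-2-yl on the saturated ring carbon would change the number in the same way with cyclopentyloxy on the carbonyl carbon as it does with isobutyl.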